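Acid dissociation of N-substituted bis-bromophenyl amidines: the cyclopentyl case

The source may report more compounds than this note shows. Statements on the series, on what has been measured and on what is new or still open speak of the compounds shown alone.

Measured in a physicochemical assay for acid dissociation:
compound 1, `CCN(C1=NCCN1)c1c(Br)cccc1Br`, gives 11.1
compound 2, `CCCN(C1=NCCN1)c1c(Br)cccc1Br`, gives 11
compound 3, `C=C(C)CN(C1=NCCN1)c1c(Br)cccc1Br`, gives 10.7

Compound 2 sits second highest of the three numbers. Its nearest neighbour is compound 1, with a step of a number 0.10 log units lower from compound 1 to compound 2 (within the scatter), and its furthest is compound 3, with a step of a number 0.30 log units lower from compound 2 to compound 3 (within the scatter); both steps lie within the scatter, so no ordering among these three can be claimed from them. Within the data shown here, the one step beyond the scatter is a number 0.40 log units lower from compound 1 to compound 3 (beyond the scatter), and it is modest.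

Compound 4, `Brc1cccc(Br)c1N(C1=NCCN1)C1CCCC1`, differs from compound 2 by cyclopentyl in place of propyl on a nitrogen on an aromatic ring. Among the measured compounds shown here, no measured pair shows a cyclopentyl entering; the steps that bear on the question are the changes on the same nitrogen substituent, methyl in place of hydrogen two bonds along the chain and 1-methylethenyl in place of ethyl on the carbon bound to the nitrogen, and both stayed within the scatter. Enlarging the group on that nitrogen has therefore moved this assay little so far, and the step to compound 4 is expected to be small, if anything slightly lower.

For compound 4 the expected value in this assay is 10.9, estimated between 10.5 and 11.3, a step of a number 0.10 log units lower from compound 2 to compound 4 (within the scatter) that is expected to stay within the scatter.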

Compound 4, acid dissociation constant: 11.2
Compound 4: the middle estimate sits 0.30 log units below what was measured; measured number inside the range.
By their numbers in this assay, from the lowest: compounds 3, 2, 1 and 4 (each within the scatter of the next, the first and the last beyond it).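

In this assay, among these compounds, a ring enters on a nitrogen on an aromatic ring for the first time, and the cyclopentyl compound cannot be told apart from its open-chain neighbours, either from the propyl compound (a number 0.20 log units higher from compound 2 to compound 4 (within the scatter)) or from the ethyl compound (a number 0.10 log units higher from compound 1 to compound 4 (within the scatter)). Ethyl, propyl and cyclopentyl thus form a group of three whose numbers all lie within the scatter of one another, so neither the added carbon count nor the ring separates them here. Among the compounds shown here, compound 3 goes against this picture: the only new step beyond the scatter, and a modest one, is a number 0.50 log units higher from compound 3 to compound 4 (beyond the scatter), so compound 3 now differs beyond the scatter from two compounds while remaining within it of compound 2. No measurement at hand bears on why the numbers fall this way.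

As far as these compounds go, it remains open whether a group carrying an amine or a carboxylic acid, or a cyclohexyl ring, on this nitrogen would stay with the three carbon-only groups. A 2-methylpropyl group in the same place would show whether the separation of compound 3 goes with its double bond or with its branching.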